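The compounds below may be only part of what the source reports. "The series", "measured", "known", "first", "only" and "open" are said of these compounds alone.

Compound 3 `CC(=O)Nc1cccc(C2CCN(CCCn3c(-c4ccc(Br)cc4)nc4ccccc43)CC2)c1` gives 5 nM in an assay for displacement of a labelled ligand from melanin-concentrating hormone receptor 1 (Homo sapiens), read by fluorescence (a higher number here means a weaker inhibitor, a lower number a stronger inhibitor), the lowest of the three numbers in the set. Compound 1 `CC(=O)Nc1cccc(C2CCN(CCCn3c(-c4cccc(C(F)(F)F)c4)nc4ccccc43)CC2)c1` gives 30 nM in this assay, and compound 2 `CC(=O)Nc1cccc(C2CCN(CCCn3c(-c4ccc(F)cc4)nc4ccccc43)CC2)c1` gives 56 nM. The steps to compound 3 were a 6.0-fold lower number from compound 1 to compound 3 (0.78 log units; beyond the scatter) and an 11-fold lower number from compound 2 to compound 3 (1.05 log units; beyond the scatter); the remaining step, a 1.9-fold higher number from compound 1 to compound 2 (0.27 log units; within the scatter), does not separate its two compounds.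

Compound 4 `CC(=O)Nc1cccc(C2CCN(CCCn3c(-c4ccc(Cl)cc4Cl)nc4ccccc43)CC2)c1` differs from compound 3 in one place: 2,4-dichlorophenyl in place of 4-bromophenyl on an aromatic carbon. The measured steps that bear on it are those in which the aryl group on the shared core was varied, above all an 11-fold lower number from compound 2 to compound 3 (1.05 log units; beyond the scatter), which showed that the halogen on that ring moves the number strongly, and a 6.0-fold lower number from compound 1 to compound 3 (0.78 log units; beyond the scatter). Among the compounds with values here, no measured pair exchanges bromo for chloro or adds a second chloro, so the direction is not fixed by the data; the halogen steps seen so far suggest that a 4-halogen heavier than fluoro keeps the number low, while the unmeasured second chloro adds uncertainty. A step of a 2.0-fold higher number from compound 3 to compound 4 (0.30 log units; within the scatter) is therefore expected, most likely a small loss within or near the scatter. Compound 4 is estimated at 10 nM, with a range from 3 nM to 35 nM.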

Compound 4, half-maximal inhibitory concentration: 3 nM
The estimate for compound 4 lay 3.3-fold (0.52 log units) above the measured number; the measured number falls inside the stated range.
By their numbers in this assay, from the lowest: compounds 4 and 3 (each within the scatter of the next); then compounds 1 and 2 (each within the scatter of the next).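

In this assay the position between two ring nitrogen atoms accepts 2,4-dichlorophenyl as readily as 4-bromophenyl: the step of a 1.7-fold lower number from compound 3 to compound 4 (0.22 log units; within the scatter) does not separate the two, so a low number here is not tied to a single bromo group. The 2,4-dichlorophenyl group also stands clear of the other two aryl groups, with a 19-fold lower number from compound 2 to compound 4 (1.27 log units; beyond the scatter) and a 10-fold lower number from compound 1 to compound 4 (1.00 log units; beyond the scatter), which places compound 4 with compound 3 and apart from compound 1 and compound 2. Nothing available accounts for these differences.

Going by these compounds, what 4-chlorophenyl alone would give, and so what the second chloro contributes, stays open. Equally open, on these data alone, is how this position responds to an aryl ring carrying a methoxy group, an amine or a carboxylic acid in place of halogen.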